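The source may hold more compounds than are shown below. What is called first, only, known or untested is meant among the compounds shown, and "the series" means these compounds.

Working notes on the series. For the measured compounds named here, compound 3 `Fc1ccc(-c2cn3ccnc3c(-c3ccc4ncn(C5CCCCC5)c4c3)n2)cc1` gives 9.02% in a functional assay on ACHN cells (Homo sapiens) for inhibition, read by sulforhodamine B assay, with a stated time of 48 h, tested at 10 uM (a lower number here means less inhibition, a higher number more inhibition at the concentration tested (going by the name of the read-out)), the lowest of the three numbers so far. Compound 2 `O=Cc1ccc(-c2cn3ccnc3c(-c3ccc4ncn(C5CCCCC5)c4c3)n2)cc1` gives 11.6%, and the step of a number 2.6 percentage points lower from compound 2 to compound 3 (within the scatter) lies within the scatter. Compound 1 `COc1ccc(-c2cn3ccnc3c(-c3ccc4ncn(C5CCCCC5)c4c3)n2)cc1` gives 61%, with a number 52 percentage points lower from compound 1 to compound 3 (beyond the scatter) and a number 49.4 percentage points lower from compound 1 to compound 2 (beyond the scatter) both large. Compound 4 `c1cn2cc(-c3ccsc3)nc(-c3ccc4ncn(C5CCCCC5)c4c3)c2n1` is not yet measured; it differs from compound 3 by thiophen-3-yl in place of 4-fluorophenyl on an aromatic carbon. Going by the values given here, no measured step exchanges the whole aromatic ring at this place, so the closest bearing comes from the small step of a number 2.6 percentage points lower from compound 2 to compound 3 (within the scatter), while a number 52 percentage points lower from compound 1 to compound 3 (beyond the scatter) shows that changes at this ring can be large. A modest upward step a number 11 percentage points higher from compound 3 to compound 4 (beyond the scatter) is expected in this assay. Compound 4 is estimated at 20%, within 5% to 45%.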

Compound 4, a percentage reported as inhibition, at one concentration (the size of the read-out at that concentration, not a potency): 5.76%
For compound 4 the middle estimate is 14.2 percentage points above the measured one; the range from low to high includes it.
By their numbers in this assay, from the lowest: compounds 4, 3 and 2 (each within the scatter of the next); then compound 1.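

An exchange of the whole aromatic ring at this position now stands in this assay: a number 3.3 percentage points lower from compound 3 to compound 4 (within the scatter) and a number 5.8 percentage points lower from compound 2 to compound 4 (within the scatter), so thiophen-3-yl falls with 4-fluorophenyl and 4-formylphenyl. The five-membered ring does not reach compound 1, with a number 55.2 percentage points lower from compound 1 to compound 4 (beyond the scatter), which leaves 4-methoxyphenyl alone among the four groups. No measurement at hand accounts for this gap. Open, as far as these compounds go, is whether the methoxy itself sets compound 1 apart, or whether an ethoxy, a hydroxyl or a dimethylamino group on the phenyl ring would do the same. Also open, from the compounds shown here alone, is what a methoxy on the thiophene ring would give.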